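Will compound 4 stay slowly cleared?

A few compounds are considered here, and "the series" means these few. Any claim that something is new, unique, unknown or untested is made for them only; others in the source may bear on it.

Measured in an ADME assay on microsomes from liver (Homo sapiens) for metabolic stability; on this read-out lower numbers stand for slow clearance and higher numbers for fast clearance:
- Compound 1 `Cc1ccc(NC(=O)c2cc(Oc3ccc(S(C)(=O)=O)cc3)cc(OC(C)C)c2)nc1`: 17 mL/min/kg
- Compound 2 `Cc1cnc(-c2cc(Oc3ccc(S(C)(=O)=O)cc3)cc(OC(C)C)c2)[nH]c1=O`: < 8 mL/min/kg (a limit)
- Compound 3 `Cc1cc(=O)[nH]c(-c2cc(Oc3ccc(S(C)(=O)=O)cc3)cc(OC(C)C)c2)n1`: < 8 mL/min/kg (a limit)

Compound 3 gives only a limit, < 8 mL/min/kg, and not a number. Compound 3 therefore sits at the limit of < 8 mL/min/kg in this assay, at which 2 of the 3 values shown sit.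

Compound 4 `COc1cnc(-c2cc(Oc3ccc(S(C)(=O)=O)cc3)cc(OC(C)C)c2)[nH]c1=O` changes one group: a group of 9 heavy atoms (5 carbon, 2 nitrogen, 2 oxygen; one six-membered aromatic ring with 2 hetero atoms) in place of a group of 8 heavy atoms (5 carbon, 2 nitrogen, 1 oxygen; one six-membered aromatic ring with 2 hetero atoms), on an aromatic carbon. The new group keeps one six-membered aromatic ring with 2 hetero atoms.

Two measured steps introduced such a ring: an at least 2.1-fold lower number from compound 1 to compound 2 (0.32 log units; beyond the scatter) and an at least 2.1-fold lower number from compound 1 to compound 3 (0.32 log units; beyond the scatter). The third, a step that the two limits leave unreadable from compound 2 to compound 3, cannot be sized. Those first two steps suggest that this ring type goes with low numbers, so no change beyond the scatter is expected in this assay. The estimated step is a step that the limit leaves unreadable from compound 3 to compound 4. For compound 4 the expected value is 7 mL/min/kg, with an estimated range from 4 mL/min/kg to 14 mL/min/kg.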

Compound 4, clearance: < 8 mL/min/kg
Compound 4: a limit, no number; the forecaster's own chance of this, stated with the estimate: 60%; the middle value is on the limit's open side.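

In this assay compound 4 gives < 8 mL/min/kg, which is a limit and not a number. Methoxy in place of methyl therefore still leaves a reading at the limit, and the new ring group again gives an at least 2.1-fold lower number from compound 1 to compound 4 (0.32 log units; beyond the scatter). The steps linking compound 4 to compound 2 and compound 3 cannot be read, as the values bunch at one floor: the limit of < 8 mL/min/kg in this assay, at which 3 of the 4 values shown sit.

On these data alone, whether methoxy or methyl gives the slower clearance stays open. So does whether a longer chain such as ethoxy, or an amine, in that place would also stay at the limit.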